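A Second Chloro on the Aromatic Ring of Compound 3

A few compounds are considered here, and "the series" means these few. Any claim that something is new, unique, unknown or untested is made for them only; others in the source may bear on it.

For the measured compounds named here, in a functional assay on IGROV-1 cells (Homo sapiens) for inhibition, read by sulforhodamine B assay, with a stated time of 48 h (a higher number here means a weaker inhibitor of growth, a lower number a stronger inhibitor of growth), compound 1 `N#C/C(=C\N1CCN(C(=O)c2ccco2)C1=S)C(=O)Nc1ccc(Cl)cc1` gives 25300 nM, and compound 2 `N#C/C(=C\N1CCN(C(=O)c2ccco2)C1=S)C(=O)c1ccccc1` gives 19400 nM; the single change a 1.3-fold lower number from compound 1 to compound 2 (0.12 log units; within the scatter) sits on a carbonyl carbon far from the aromatic ring. Compound 3 `O=CN1CCN(c2ccc(Cl)cc2)C1=S` gives 14200 nM, the lowest of the three numbers, yet within the scatter of both others. Compound 4 `O=CN1CCN(c2ccc(Cl)c(Cl)c2)C1=S` differs from compound 3 by chloro in place of hydrogen on an aromatic carbon. Going by the values given here, no measured step touches this ring, so the one known step offers no guide to the size or direction of the change. The step of a 1.2-fold lower number from compound 3 to compound 4 (0.07 log units; within the scatter) is therefore expected to stay within the scatter. Compound 4 is estimated at 12000 nM, in a range from 5000 nM to 30000 nM.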

Compound 4, concentration for 50% growth inhibition: 15100 nM
Compound 4: the middle estimate sits 1.3-fold (0.10 log units) below what was measured; the measured number falls inside the stated range.
By their numbers in this assay, from the lowest: compounds 3, 4, 2 and 1 (each within the scatter of the next).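

In this assay, for the compounds shown here, chloro in place of hydrogen on this aromatic carbon, ortho to a chloro group, gives a 1.1-fold higher number from compound 3 to compound 4 (0.03 log units; within the scatter) and is the only measured step on this ring. A single added chlorine at this position therefore produces no change that can be told apart from the usual scatter of the measurement. Nothing measured here bears on why this is so.

Going by these compounds, whether a larger group at this position, such as an amine, a carboxylic acid or a longer chain, would move the number beyond the scatter stays open. Also open, on these data alone, is whether chloro at other carbons of this ring would behave the same way.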